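The compounds below may be only part of what the source reports. "The series", "measured", "known", "first", "only" and "open" are said of these compounds alone.

Compound 2 `Cc1ccccc1-n1nc(C)c(C(=O)Nc2ccc3ccccc3n2)c1C` holds the higher of the two solubility numbers known here: in a physicochemical assay for solubility, read by HPLC, in phosphate buffer, with a stated time of 6 h, at pH 7.4 (a lower number here means a less soluble compound, a higher number a more soluble compound), compound 2 gives 6.7 ug/mL, while compound 1 `Cc1ccccc1-n1nnc(C(=O)Nc2ccc3ccccc3n2)c1C` gives 0.11 ug/mL. Compound 3 `CCc1ccccc1-n1nc(C)c(C(=O)Nc2ccc3ccccc3n2)c1C` differs from compound 2 in one place: methyl in place of hydrogen on a saturated chain carbon bound to an aromatic carbon. Going by the values given here, no measured pair shows what this change does in this assay, so any expectation rests on the change itself. A small downward step, a 1.9-fold lower number from compound 2 to compound 3 (0.28 log units; within the scatter), is expected, possibly near the edge of the scatter. Compound 3 is therefore estimated at 3.5 ug/mL, with a range from 1 ug/mL to 12 ug/mL.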

Compound 3, solubility: 5.2 ug/mL
The estimate for compound 3 lay 1.5-fold (0.17 log units) below the measured number, and the stated range covers the measured number.
By their numbers in this assay, from the lowest: compound 1; then compounds 3 and 2 (each within the scatter of the next).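

Going from 2-methylphenyl to 2-ethylphenyl gives the first measured step at this position in this assay, and it is a 1.3-fold lower number from compound 2 to compound 3 (0.11 log units; within the scatter) and so cannot be told apart from no change. On this core, then, a methyl added on a saturated chain carbon bound to an aromatic carbon leaves the solubility reading indistinguishable, which compound 1 and compound 2 could not show, since they differ elsewhere. Nothing measured here gives a reason for this result.

Going by these compounds, whether a longer chain such as propyl, or an amine on that chain, would also leave the number within the scatter stays open. A single step also cannot show whether the same change would behave alike on the core of compound 1.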